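Removing the bromo group from compound 3

The compounds below may be only part of what the source reports. "The series", "measured", "known", "first", "only" and "open" are said of these compounds alone.

Values in a functional assay on B16-F10 cells (Mus musculus) for cytotoxicity; a higher number here means a weaker inhibitor, a lower number a stronger inhibitor:
- Compound 1 `O=c1oc2ccccc2c2nc3c(ccc4cc[nH]c43)c(-c3cccnc3Cl)c12`: 70700 nM
- Compound 2 `O=c1oc2ccccc2c2nc3c(ccc4cc[nH]c43)c(-c3ccccn3)c12`: 70700 nM
- Compound 3 `O=c1oc2ccccc2c2nc3c(ccc4cc[nH]c43)c(-c3ccccc3Br)c12`: 70700 nM

Compound 3 stands level with the other two, and all three show the same figure. The next compound, compound 4 `O=c1oc2ccccc2c2nc3c(ccc4cc[nH]c43)c(-c3ccccc3)c12`, has hydrogen in place of bromo on an aromatic carbon, which turns the 2-bromophenyl group into phenyl.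

Among the measured compounds shown here, no measured step removes the bromo alone. The nearest evidence comes from three swaps of the aromatic group on the shared core: no change at the digits printed from compound 1 to compound 2 (within the scatter), no change at the digits printed from compound 1 to compound 3 (within the scatter) and no change at the digits printed from compound 2 to compound 3 (within the scatter). None of these steps goes beyond the scatter, even though the groups differ considerably. On this evidence, no shift beyond the scatter is expected in this assay, and the expected step is no change at the digits printed from compound 3 to compound 4 (within the scatter). For the measured compounds named here, with only three compounds, this expectation remains tentative. The estimated value for compound 4 is 70700 nM, with an expected range from 35000 nM to 100000 nM.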

Compound 4, half-maximal inhibitory concentration: 70700 nM
Beside the measured number, compound 4's estimate shows no gap at the digits printed; measured number inside the range.
By their numbers in this assay, from the lowest: compounds 1, 2, 3 and 4 (each within the scatter of the next).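

In this assay, replacing bromo with hydrogen shows no change at the digits printed from compound 3 to compound 4 (within the scatter), the first direct test of removing a single group at this place on the aromatic ring. The bare phenyl group also matches both pyridine-bearing compounds, with no change at the digits printed from compound 2 to compound 4 (within the scatter) and no change at the digits printed from compound 1 to compound 4 (within the scatter), so the unsubstituted ring gives a simple reference and the four aromatic groups shown cannot be told apart in this assay. Nothing available here explains this flat result.

The compounds shown leave open whether any group on this ring can move the number at all, for example an amine, a carboxylic acid or a longer chain. They also leave open whether a change elsewhere on the shared core would have a larger effect.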